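Toxicity notes: from compound 3 to compound 4

A few compounds are considered here, and "the series" means these few. Any claim that something is new, unique, unknown or untested is made for them only; others in the source may bear on it.

In an ADME assay on CEM-SS cells (Homo sapiens) for cytotoxicity, read by XTT assay, with a stated time of 6 days (on this read-out lower numbers stand for higher toxicity in this test and higher numbers for lower toxicity in this test), compound 3 (`CCCC(=O)OCSc1ccccc1C(=O)OCC(N)=O`) gives 82.1 uM, the higher of the two actual numbers in the series. Compound 2 (`CCCC(=O)OCSc1ccccc1C(=O)Nc1cccc(C(N)=O)c1`) gives the lower number, 17.5 uM. Compound 1 (`CCCC(=O)OCSc1ccccc1C(=O)NCC(N)=O`) gives > 100 uM, which is a limit of the assay.

Compound 4 (`CCCC(=O)OCSc1ccccc1C(=O)N(C)CC(=O)NC`) differs from compound 3 by methyl((methylcarbamoyl)methyl)amino in place of carbamoylmethoxy on a carbonyl carbon. Going by the values given here, one measured step bears on this change, an at least 1.2-fold lower number from compound 1 to compound 3 (0.08 log units; that floor lies within the scatter). Its size rests on (the limit of > 100 uM in this assay, at which 1 of the 3 values shown sits). Among the compounds with values here, the entering group resembles the (carbamoylmethyl)amino group of compound 1, but no measured step covers its added methyl groups. Compound 1, at > 100 uM, therefore offers only a loose guide, and a small rise in the number is the most that can be expected. No step beyond the scatter is expected in this assay, and the estimated change is a 1.2-fold higher number from compound 3 to compound 4 (0.06 log units; within the scatter). A report of compound 4 as a limit would not be surprising. The expected value for compound 4 is 95 uM, with an estimated range of 40 uM to 200 uM.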

Compound 4, half-maximal toxic concentration: 62.5 uM
Estimate against measurement, compound 4: 1.5-fold (0.18 log units) above; the measured number falls inside the stated range.
By their numbers in this assay, from the lowest: compound 2; then compounds 4 and 3 (each within the scatter of the next). At a limit, above all of these: compound 1.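

In this assay, going by these compounds alone, exchanging carbamoylmethoxy for methyl((methylcarbamoyl)methyl)amino on this carbonyl carbon gives a 1.3-fold lower number from compound 3 to compound 4 (0.12 log units; within the scatter), so the larger entering group brings no step that can be separated from the scatter. Compound 1 gives > 100 uM, which is a limit. The comparison with that compound shows only an at least 1.6-fold lower number from compound 1 to compound 4 (0.20 log units; that floor lies within the scatter), and this size is a floor rather than a measured gap: the limit of > 100 uM in this assay, at which 1 of the 4 values shown sits.

From the compounds shown here alone, whether compound 4 truly stands apart from compound 1 remains open, as does what each added methyl group contributes on its own. Going by these compounds, how a group ending in a carboxylic acid, or a longer chain, on this carbonyl carbon would read in this assay also remains open.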